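Fluoro in place of methoxy on the shared core of compound 2

The compounds below may be only part of what the source reports. "The series", "measured", "known", "first", "only" and "open" are said of these compounds alone.

Compound 1, `COc1ccc(-c2nc(C(=O)/C=C\Nc3ccc4[nH]ccc4c3)c3ccccn23)cc1`, in a functional assay on B16-F10 cells (Mus musculus) for cytotoxicity, read by MTT assay, with a stated time of 48 h; a lower number here means a stronger inhibitor, a higher number a weaker inhibitor: 5120 nM
Compound 2, `COc1ccc(-c2nc(C(=O)/C=C\Nc3ccc(Cl)cc3)c3ccccn23)cc1`, in this assay: 1240 nM
Compound 3, `COc1ccc(N/C=C\C(=O)c2nc(-c3ccc(OC)cc3)n3ccccc23)cc1`, in this assay: 2120 nM

Compound 2 gives the lowest of the three numbers, though compound 3 lies within the scatter of it, and only compound 1 stands apart. Two of the measured steps change the aryl group on the amine nitrogen: a 4.1-fold lower number from compound 1 to compound 2 (0.62 log units; beyond the scatter) and a 2.4-fold lower number from compound 1 to compound 3 (0.38 log units; beyond the scatter). The third, a 1.7-fold higher number from compound 2 to compound 3 (0.23 log units; within the scatter), swaps a halogen for a methoxy group and stays within the scatter.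

Compound 4, `O=C(/C=C\Nc1ccc(Cl)cc1)c1nc(-c2ccc(F)cc2)n2ccccc12`, differs from compound 2 by fluoro in place of methoxy on an aromatic carbon. Among the compounds with values here, no measured step touches this ring; the nearest guide is the methoxy-for-chloro swap, which was within the scatter. A step within the scatter is therefore expected, a 1.2-fold higher number from compound 2 to compound 4 (0.08 log units; within the scatter). Compound 4 is estimated at 1500 nM in this assay, between 500 nM and 4500 nM.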

Compound 4, half-maximal inhibitory concentration: 11000 nM
Compound 4: middle estimate off by 7.3-fold (0.87 log units), on the low side; the measured number lies above the stated range.
By their numbers in this assay, from the lowest: compounds 2 and 3 (each within the scatter of the next); then compound 1; then compound 4.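

In this assay, the change from 4-methoxyphenyl to 4-fluorophenyl gives an 8.9-fold higher number from compound 2 to compound 4 (0.95 log units; beyond the scatter). Within the data shown here, this shows that the group on this ring, which no earlier step touched, strongly affects the number, and that swapping methoxy here is not a neutral change. Nothing available accounts for this step. The compounds shown leave open whether the step follows from the entry of fluoro or the departure of methoxy. A hydroxy group or an amine at this place would help separate the two.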